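A few compounds are considered here, and "the series" means these few. Any claim that something is new, unique, unknown or untested is made for them only; others in the source may bear on it.

Measured so far in a functional assay on MGC-803 cells (Homo sapiens) for inhibition, read by MTT assay, with a stated time of 48 h; a higher number here means a weaker inhibitor, a lower number a stronger inhibitor:
- compound 1 `C/C=C/C(=O)N(Cc1ccc(OC)c(N)c1)c1cc(OC)c(OC)c(OC)c1`: 150 nM
- compound 2 `C/C=C/C(=O)N(Cc1ccc(OC)c(Br)c1)c1cc(OC)c(OC)c(OC)c1`: 6430 nM
- compound 3 `C/C=C/C(=O)N(Cc1cccc(O)c1)c1cc(OC)c(OC)c(OC)c1`: 14100 nM

Compound 3 has the highest number of the three, with compound 2 nearest to it. The next analogue, compound 4 `C/C=C/C(=O)N(Cc1ccc(OC)cc1)c1cc(OC)c(OC)c(OC)c1`, has 4-methoxyphenyl in place of 3-hydroxyphenyl on a saturated chain carbon bound to an amide-type nitrogen.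

Compound 2 is the closest guide, since its 3-bromo-4-methoxyphenyl group also carries the methoxy. The measured step to compound 3 is only modest: a 2.2-fold higher number from compound 2 to compound 3 (0.34 log units; beyond the scatter). The two large steps, a 43-fold higher number from compound 1 to compound 2 (1.63 log units; beyond the scatter) and a 94-fold higher number from compound 1 to compound 3 (1.97 log units; beyond the scatter), both start from compound 1, and compound 4 lacks its amino group. A return to the level of compound 1 is therefore not expected.

The expected change in this assay is modest and toward a lower number: a 2.8-fold lower number from compound 3 to compound 4 (0.45 log units; beyond the scatter). For compound 4 the estimated value is 5000 nM (expected range 1500 nM to 15000 nM).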

Compound 4, half-maximal inhibitory concentration: 450 nM
Compound 4: the middle estimate sits 11-fold (1.05 log units) above what was measured; the whole stated range lies above it.
By their numbers in this assay, from the lowest: compound 1; then compound 4; then compound 2; then compound 3.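

In this assay, the bare 4-methoxyphenyl group on the saturated chain carbon bound to the amide-type nitrogen retains most of the level of compound 1, and its exchange for 3-hydroxyphenyl gives a large change (a 31-fold lower number from compound 3 to compound 4 (1.50 log units; beyond the scatter)). Removing the amino group from the aromatic carbon costs only a modest step (a 3.0-fold higher number from compound 1 to compound 4 (0.48 log units; beyond the scatter)), so the amino group is not required for a number in this range. The large cost seen earlier with compound 2 is instead tied to the bromo group, as hydrogen on that aromatic carbon gives a large step (a 14-fold lower number from compound 2 to compound 4 (1.15 log units; beyond the scatter)).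

From the compounds shown here alone, how a fluoro, chloro, methyl or hydroxy group on that same aromatic carbon would compare with hydrogen, amino and bromo remains open. Nothing available explains why these groups differ so widely.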